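Swapping a urea for a sulfonyl on the piperidine nitrogen

The source may report more compounds than this note shows. Statements on the series, on what has been measured and on what is new or still open speak of the compounds shown alone.

Compound 3, `CCNC(=O)N1CCC(CN(C2Cc3cc(C#N)ccc3N(Cc3cncn3C)C2)S(=O)(=O)c2ccccn2)CC1`, was tested in an ADME assay on Caco-2 cells (Homo sapiens) for permeability, in the apical to basolateral direction (on this read-out lower numbers stand for lower permeability and higher numbers for higher permeability), and compound 3 gives 0.6 10^-6 cm/s. Two close relatives set the frame. Compound 1, `Cn1cncc1CN1CC(N(Cc2ccc(S(C)(=O)=O)cc2)S(=O)(=O)c2ccccn2)Cc2cc(C#N)ccc21`, gives 0.2 10^-6 cm/s in this assay, and compound 2, `CC(=O)N1CCC(CN(C2Cc3cc(C#N)ccc3N(Cc3cncn3C)C2)S(=O)(=O)c2ccccn2)CC1`, gives 0.5 10^-6 cm/s. Compound 3 is thus clearly separated from compound 1 but not from compound 2: the record shows a 3.0-fold higher number from compound 1 to compound 3 (0.48 log units; beyond the scatter), a 2.5-fold higher number from compound 1 to compound 2 (0.40 log units; beyond the scatter) and a 1.2-fold higher number from compound 2 to compound 3 (0.08 log units; within the scatter).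

Compound 4, `CC(C)S(=O)(=O)N1CCC(CN(C2Cc3cc(C#N)ccc3N(Cc3cncn3C)C2)S(=O)(=O)c2ccccn2)CC1`, is not yet measured. It differs from compound 3 in one place: isopropylsulfonyl in place of ethylcarbamoyl on an amine nitrogen in a ring. Among the measured compounds shown here, the only measured step that touches this same position is the one from compound 2 to compound 3, where ethylamino replaced methyl on the carbonyl carbon and the numbers stayed within the scatter. The larger steps from compound 1 exchange a whole ring-bearing group elsewhere and say little about a sulfonyl on the ring nitrogen. For the measured compounds named here, no measured pair tests a sulfonyl there, so the expectation is a step of no more than the scatter in either direction, no change at the digits printed from compound 3 to compound 4 (within the scatter). Compound 4 is therefore estimated at 0.6 10^-6 cm/s, with a range from 0.3 10^-6 cm/s to 1.2 10^-6 cm/s.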

Compound 4, apparent permeability: 0.1 10^-6 cm/s
Beside the measured number, compound 4's estimate is 6.0-fold (0.78 log units) above it, and the stated range ends above it.
By their numbers in this assay, from the lowest: compounds 4 and 1 (each within the scatter of the next); then compounds 2 and 3 (each within the scatter of the next).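

The earlier compounds shown here showed only that acetyl and ethylcarbamoyl on the piperidine nitrogen read alike, so this position could have seemed insensitive to what it carries, but in this assay the isopropylsulfonyl group breaks that picture, with a 6.0-fold lower number from compound 3 to compound 4 (0.78 log units; beyond the scatter) and a 5.0-fold lower number from compound 2 to compound 4 (0.70 log units; beyond the scatter) as the two steps that show it. The gain seen earlier on moving from the 4-(methylsulfonyl)phenyl group to an acylated piperidine therefore depends on what sits on the ring nitrogen and does not come with the piperidine alone, since a 2.0-fold lower number from compound 1 to compound 4 (0.30 log units; within the scatter) leaves the sulfonyl compound inseparable from the aryl compound. Nothing measured here explains why the sulfonyl group gives the lower number.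

The change swaps the linking carbonyl for a sulfonyl and also alters the carbon group attached to it, so the sulfonyl and the isopropyl cannot be told apart in these compounds. An ethylsulfonyl group on the same nitrogen would test the first of these, and an isopropylcarbamoyl group the second, while a free amine there would show how the ring nitrogen reads with no group on it at all.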